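This account rests on a few compounds, and the source may have more. Where it says the series, first, only, none or still open, it means among the compounds named here.

Compound 1 `Oc1ccc(CNc2ncnc3c2ncn3C2CCCCO2)cc1` gives in an ADME assay on MCF7 cells (Homo sapiens) for cytotoxicity, with a stated time of 72 h (a lower number here means a stronger inhibitor, a higher number a weaker inhibitor), a limit of the assay, > 100000 nM.
Compound 2 `COc1cc(CNc2ncnc3c2ncn3C2CCCCO2)ccc1O` gives in this assay a limit of the assay, > 100000 nM.
Compound 3 `COc1cc(CNc2ncnc3c2ncn3C2CCCO2)cc(OC)c1` gives in this assay a limit of the assay, > 100000 nM.

All three measured compounds sit at the limit of > 100000 nM in this assay, at which 3 of the 3 values shown sit. From compound 1 to compound 2 the change is methoxy in place of hydrogen on an aromatic carbon, and the step it made, a step that the two limits leave unreadable from compound 1 to compound 2, cannot be sized. The difference between the cores of compound 1 and compound 3 is not broken down here. Compound 4 `COc1cc(CNc2ncnc3c2ncn3C2CCCO2)cc(OC)c1OC` differs from compound 3 by methoxy in place of hydrogen on an aromatic carbon, the same kind of change, though here the place is ortho to two methoxy groups and para to a large group, whereas before it was ortho to a hydroxy group and meta to a large group. Within the data shown here, because the limit of > 100000 nM in this assay, at which 3 of the 3 values shown sit, holds every value so far, compound 4 is expected to stay at that limit too. The expected step is a number no higher from compound 3 to compound 4 (the limit leaves the size open). Compound 4 is estimated at 100000 nM, between 30000 nM and 300000 nM.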

Compound 4, half-maximal inhibitory concentration: > 100000 nM
Compound 4 gave a limit, no number (the forecaster's own chance of this, stated with the estimate: 85%); the middle value sits exactly at the limit.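

Compound 3 and compound 4 both give only a limit, so no step between them can be read, and every value shown sits at the same limit: the limit of > 100000 nM in this assay, at which 4 of the 4 values shown sit.

The compounds shown leave open how strongly any of them acts in this assay, and whether methoxy in place of hydrogen on an aromatic carbon changes that.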